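Drawing the Double Bond the Other Way Round

This account rests on a few compounds, and the source may have more. Where it says the series, first, only, none or still open, it means among the compounds named here.

Compound 2 `C/C(=N\NC(=S)Nc1ccc(F)cc1)c1ccccn1` in a functional assay on T98G cells (Homo sapiens) for cytotoxicity, read by MTT assay, with a stated time of 48 h (on this read-out lower numbers stand for stronger inhibition and higher numbers for weaker inhibition), gives 17 nM. Compound 1 `CC(=NNC(=S)Nc1ccc(F)cc1)c1ccccn1` gives 17 nM in this assay, and the step of no change at the digits printed from compound 1 to compound 2 (within the scatter) shows nothing beyond the scatter; what separates the two is the fact that one of compounds 1 and 2 is drawn with a defined configuration and the other without, at the place where they differ. Compound 3 `C/C(=N\NC(=S)Nc1ccccc1)c1ccccn1` gives 6.81 nM, so the step of a 2.5-fold lower number from compound 2 to compound 3 (0.40 log units; beyond the scatter) is the only movement beyond the scatter here, and compound 2 stands level with compound 1 as the higher pair of the three numbers. Compound 4 `C/C(=N/NC(=S)Nc1ccc(F)cc1)c1ccccn1` differs from compound 2 by the two compounds have the same atoms and bonds and differ only in configuration as drawn: 1 of 1 stereo elements differ; a double bond is drawn E in compound 2 and Z in compound 4. For the measured compounds named here, the one measured step touching only a drawn configuration, no change at the digits printed from compound 1 to compound 2 (within the scatter), was flat, so no step beyond the scatter is expected in no change at the digits printed from compound 2 to compound 4 (within the scatter). Compound 4 is expected to give about 17 nM, between 8 nM and 36 nM.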

Compound 4, half-maximal inhibitory concentration: 17 nM
Estimate against measurement, compound 4: no gap at the digits printed, and the stated range covers the measured number.
By their numbers in this assay, from the lowest: compound 3; then compounds 1, 2 and 4 (each within the scatter of the next).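

In this assay, for the compounds shown here, the earlier compounds set a drawn double bond only against an undrawn one, whereas here the two defined configurations meet directly: no change at the digits printed from compound 2 to compound 4 (within the scatter). The undrawn form also holds level with the Z drawing: no change at the digits printed from compound 1 to compound 4 (within the scatter). With fluoro on the aromatic carbon, then, the configuration as drawn at this double bond moves nothing in this assay.

As far as these compounds go, it remains open whether the Z drawing would stay equally flat with hydrogen in place of fluoro, as in compound 3. From the compounds shown here alone, it is also open how a methoxy group or an amine on that aromatic carbon would shift the number.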